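The compounds below may be only part of what the source reports. "The series", "measured", "known", "first", "only" and "open" are said of these compounds alone.

Measured so far: compound 1 `Cc1cn2c(-c3cn[nH]c3)cnc2c(Nc2cc(Cn3cccn3)ns2)n1`, "not determined" (no result reported); compound 2 `Cc1cn2c(-c3cn[nH]c3)cnc2c(Nc2cc(Cn3cccc(C)c3=O)ns2)n1`, "not determined" (no result reported); compound 3 `Cc1cn2c(-c3cn[nH]c3)cnc2c(Nc2cc(Cc3ncccn3)ns2)n1`, 701 ng.h/mL.

Compound 1 and compound 2 share a core and a thiazole-linked methylene arm, and in an ADME assay on the whole organism for pharmacokinetics, with Rattus norvegicus as the target, with a stated time of 6 h, at a dose of 10 mg/kg by the oral route (a higher number here means more compound in the circulation at the dose given, a lower number less compound in the circulation), compound 1 has no recorded number. Compound 2 likewise has no single number in this assay; it stands beside one further entry without a number, so there is nothing to rank it against. Compound 3 gives 701 ng.h/mL in this assay. The compound now in question is compound 4 `Cc1ccnc(Cc2cc(Nc3nc(C)cn4c(-c5cn[nH]c5)cnc34)sn2)c1`. It differs from compound 2 in one place: a group of 7 heavy atoms (6 carbon, 1 nitrogen; one six-membered aromatic ring with 1 hetero atom) in place of a group of 8 heavy atoms (6 carbon, 1 nitrogen, 1 oxygen; one six-membered aromatic ring with 1 hetero atom), on a saturated chain carbon bound to an aromatic carbon. Within the data shown here, no measured step across this change exists, so its size is unknown; any direction is possible, and a shift within the usual scatter is as likely as one beyond it. In this assay compound 4 is expected to give about 500 ng.h/mL, within a range from 120 ng.h/mL to 2000 ng.h/mL, an estimate resting on compound 3 because it gives 701 ng.h/mL with a related arm.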

Compound 4, area under the concentration-time curve: 1850 ng.h/mL
Compound 4: the middle estimate sits 3.7-fold (0.57 log units) below what was measured, within the range that was stated.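

In this assay, the group on the saturated chain carbon bound to an aromatic carbon now has its first measured step: with 4-methylpyridin-2-yl in place of pyrimidin-2-yl, there is a 2.6-fold higher number from compound 3 to compound 4 (0.42 log units; beyond the scatter), so the read-out responds to a change at this position. Steps involving compound 1 or compound 2 cannot be read, as neither compound has a number. Nothing at hand explains the difference between compound 3 and compound 4.

This single step does not separate the contribution of the methyl group from that of the ring exchange, and an unsubstituted pyridin-2-yl group would bear on that question. From the compounds shown here alone, how a phenyl ring or an amine at this place would read in this assay also remains open.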